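Shortening the Chain to a Single Double Bond

The compounds below may be only part of what the source reports. "The series", "measured", "known", "first", "only" and "open" are said of these compounds alone.

Compound 1 `CCCCCCCC/C=C\CCCCCCCC(=O)OCC1CCCCO1`: 35%
Compound 2 `CC/C=C\C/C=C\C/C=C\CCCCCCCC(=O)OCC1CCCCO1`: 33%
Compound 3 `CCCCC/C=C\C/C=C\CCCCCCCC(=O)OCC1CCCCO1`: 38%

These three esters share one core and differ only in their fatty chain, all measured in an assay on membranes from cerebellum for inhibition of Monoglyceride lipase (Rattus norvegicus), tested at 100 uM; a higher number here means more inhibition at the concentration tested (going by the name of the read-out), a lower number less inhibition. Compound 3 stands where the steps of a number 3 percentage points higher from compound 1 to compound 3 (within the scatter) and a number 5 percentage points higher from compound 2 to compound 3 (within the scatter) place it, both within the scatter, so the three cannot be ranked. Compound 4 `CCCCCC/C=C\CCCCCCCC(=O)OCC1CCCCO1` carries the change (pentyl in place of hept-1-en-1-yl on a saturated chain carbon bound to a double-bonded chain carbon). Every chain edit seen so far, including a number 2 percentage points lower from compound 1 to compound 2 (within the scatter), stayed within the scatter, which suggests this further edit will do the same. Compound 4 is therefore expected to give about 35%, with a range from 22% to 48%. The step of a number 3 percentage points lower from compound 3 to compound 4 (within the scatter) is thus estimated to remain within the scatter.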

Compound 4, a percentage reported as inhibition, at one concentration (the size of the read-out at that concentration, not a potency): 36%
The estimate for compound 4 lay 1 percentage points below the measured number; measured number inside the range.
By their numbers in this assay, from the lowest: compounds 2, 1, 4 and 3 (each within the scatter of the next).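

In this assay, pentyl in place of hept-1-en-1-yl gives a number 2 percentage points lower from compound 3 to compound 4 (within the scatter), and pentyl in place of hepta-1,4-dien-1-yl gives a number 3 percentage points higher from compound 2 to compound 4 (within the scatter). Chain length now joins the number of double bonds as an edit that leaves this reading within the scatter: hydrogen in place of ethyl, with the double bond kept, gives a number 1 percentage points higher from compound 1 to compound 4 (within the scatter). No measurement here offers an explanation for this flat result. The compounds shown leave open whether a carboxylic acid or an amine in place of pentyl would shift the number beyond the scatter.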